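This account rests on a few compounds, and the source may have more. Where it says the series, first, only, none or still open, it means among the compounds named here.

Measured so far in a functional assay on KB cells (Homo sapiens) for antiproliferative activity, read by sulforhodamine B assay, with a stated time of 3 days; a higher number here means that more compound is needed for the effect, a lower number that less compound is needed:
compound 1 `CCC1=C(O)c2c(oc(-c3ccc(CC)cc3)cc2=O)C(CC)(CC)C1=O`: 21.9 uM
compound 3 `CCC1=C(O)c2c(oc(-c3ccccc3C)cc2=O)C(CC)(CC)C1=O`: 40.9 uM
Compound 2 `CCOc1ccc(-c2cc(=O)c3c(o2)C(CC)(CC)C(=O)C(CC)=C3O)cc1` returned only a limit of this assay, > 52.4 uM.

Compound 3 holds the higher of the two numbers; its nearest neighbour is compound 1, and a 1.9-fold higher number from compound 1 to compound 3 (0.27 log units; within the scatter). Compound 4 `CCC1=C(O)c2c(oc(-c3ccc(O)c(C)c3C)cc2=O)C(CC)(CC)C1=O` differs from compound 3 by 4-hydroxy-2,3-dimethylphenyl in place of 2-methylphenyl on an aromatic carbon. The closest measured step is an at least 2.3-fold higher number from compound 1 to compound 2 (0.37 log units; beyond the scatter), where ethoxy replaced ethyl on the aryl ring and the number rose to a limit; an at least 1.2-fold lower number from compound 2 to compound 3 (0.10 log units; that floor lies within the scatter) stays within the scatter. A modest rise in this assay is therefore expected, a 1.3-fold higher number from compound 3 to compound 4 (0.13 log units; within the scatter), with a real chance that only a limit is returned. Compound 4 is estimated at 55 uM, between 22 uM and 140 uM.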

Compound 4, concentration for half-maximal effect: 6.5 uM
The estimate for compound 4 lay 8.5-fold (0.93 log units) above the measured number; measured number below the stated range.
By their numbers in this assay, from the lowest: compound 4; then compounds 1 and 3 (each within the scatter of the next). At a limit, above all of these: compound 2.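

On the aromatic carbon next to the ring oxygen, 4-hydroxy-2,3-dimethylphenyl gives what the earlier aryl groups did not, a drop beyond the scatter in this assay: a 6.3-fold lower number from compound 3 to compound 4 (0.80 log units; beyond the scatter), and a 3.4-fold lower number from compound 1 to compound 4 (0.53 log units; beyond the scatter). Against the 4-ethoxyphenyl group the change reads an at least 8.0-fold lower number from compound 2 to compound 4 (0.90 log units; beyond the scatter). Compound 2 gives only a limit: the limit of > 52.4 uM in this assay, at which 1 of the 4 values shown sits.

The compounds shown do not separate the 4-hydroxy group from the second methyl group. On these data alone, whether an amine or a carboxylic acid in place of that hydroxy group would hold the lower number stays open.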